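The compounds below may be only part of what the source reports. "The series", "measured", "known", "first", "only" and "open" are said of these compounds alone.

Compound 1 `OC[C@H]1O[C@@H](n2cnc3c(COc4ccccc4)ncnc32)[C@H](O)[C@@H]1O`: in a functional assay on Huh-7 cells (Homo sapiens) for cytotoxicity, read by MTT assay, with a stated time of 3 days (on this read-out higher numbers stand for lower toxicity in this test and lower numbers for higher toxicity in this test), compound 1 reaches only an assay limit, > 100000 nM.
Compound 2 `OC[C@H]1O[C@@H](n2cnc3c(Cn4ccc5ccccc54)ncnc32)[C@H](O)[C@@H]1O`: in this assay compound 2 likewise sits at a limit, > 250000 nM.
Compound 3 `CN(Cc1ccccc1)Cc1ncnc2c1ncn2[C@@H]1O[C@H](CO)[C@@H](O)[C@H]1O`: in this assay compound 3 gives 9000 nM.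

Compound 2 therefore stands at the upper edge of what the this assay can report: its value is a limit and not a number, as is that of compound 1, so the step that the two limits leave unreadable from compound 1 to compound 2 cannot be read. Compound 4 `OC[C@H]1O[C@@H](n2cnc3c(CN4CCCCC4)ncnc32)[C@H](O)[C@@H]1O` has not yet been measured in the this assay. It differs from compound 2 in one place: piperidin-1-yl in place of 1H-indol-1-yl on a saturated chain carbon bound to an aromatic carbon.

The measured steps that bear on this change both lead away from the limits toward compound 3, which carries a benzyl(methyl)amino group on the same saturated chain carbon. The step of an at least 27-fold lower number from compound 2 to compound 3 (1.44 log units; beyond the scatter) and the step of an at least 11-fold lower number from compound 1 to compound 3 (1.04 log units; beyond the scatter) are both large and beyond the scatter. Compound 4 also carries a nitrogen-linked saturated amine at this position, though a piperidin-1-yl rather than a benzyl(methyl)amino group, so a lower number than the limit of compound 2 is expected, but with less confidence than for compound 3. The expected step is an at least 4.1-fold lower number from compound 2 to compound 4 (0.61 log units; beyond the scatter). For compound 4 the estimate is 60000 nM, between 10000 nM and 250000 nM.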

Compound 4, half-maximal cytotoxic concentration: 87000 nM
Compound 4: middle estimate off by 1.5-fold (0.16 log units), on the low side; the range from low to high includes it.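

With piperidin-1-yl in place of 1H-indol-1-yl on a saturated chain carbon bound to an aromatic carbon, this assay gives an at least 2.8-fold lower number from compound 2 to compound 4 (0.45 log units; beyond the scatter), and this change now has a readable floor. A nitrogen-linked group at this place does not by itself match compound 3, as piperidin-1-yl in place of benzyl(methyl)amino gives a 9.7-fold higher number from compound 3 to compound 4 (0.99 log units; beyond the scatter), and among the amines shown the number therefore depends on which amine is present. Against phenoxy, the comparison gives an at least 1.1-fold lower number from compound 1 to compound 4 (0.06 log units; that floor lies within the scatter), and with that floor inside the scatter it sets no order between the two compounds.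

Going by these compounds, the full size of the step from the indole compound stays open, and the step from compound 1 to compound 2 cannot be read, because compound 2 holds only a limit: the limit of > 250000 nM in this assay, at which 1 of the 4 values shown sits. Also open is whether another amine, such as dimethylamino or morpholin-4-yl, would give a number nearer to that of compound 3 or to that of compound 4.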